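Naphthalen-1-yl Replaces 4-Methylphenyl on the Sulfur-Bound Arm

This account rests on a few compounds, and the source may have more. Where it says the series, first, only, none or still open, it means among the compounds named here.

Compound 1 `C/C(C#Cc1ccccc1)=N\N/C(N)=N/S(=O)(=O)c1cc(C)c(Cl)cc1SCc1ccc(C)cc1` gives 13000 nM in a functional assay on HCT-116 cells (Homo sapiens) for antiproliferative activity, read by MTT assay, with a stated time of 72 h; a lower number here means a stronger inhibitor, a higher number a weaker inhibitor; compound 2 `Cc1cc(S(=O)(=O)/N=C(\N)N/N=C/C#Cc2ccccc2)c(SCc2ccc(Cl)cc2)cc1Cl` gives 8000 nM. Compound 1 carries the higher figure of the two, but the gap lies within the usual scatter, so the two stand together. Compound 3 `C/C(C#Cc1ccccc1)=N\N/C(N)=N/S(=O)(=O)c1cc(C)c(Cl)cc1SCc1cccc2ccccc12` is not yet measured and differs from compound 1 by naphthalen-1-yl in place of 4-methylphenyl on a saturated chain carbon bound to a sulfur. Going by the values given here, no measured pair shows the effect of this change, so its direction is open; the step of a 1.6-fold lower number from compound 1 to compound 3 (0.21 log units; within the scatter) implied here is expected to be small, perhaps not beyond the scatter. Compound 3 is estimated at 8000 nM, within 3000 nM to 25000 nM.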

Compound 3, half-maximal inhibitory concentration: 105000 nM
Compound 3: the middle estimate sits 13-fold (1.12 log units) below what was measured, outside the stated range (above it).
By their numbers in this assay, from the lowest: compounds 2 and 1 (each within the scatter of the next); then compound 3.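

Putting naphthalen-1-yl in place of 4-methylphenyl on a saturated chain carbon bound to a sulfur gives an 8.1-fold higher number from compound 1 to compound 3 (0.91 log units; beyond the scatter) in this assay. This shows that activity at this position depends on the group attached, and that the two-ring group is poorly tolerated here. Compound 1 and compound 2 differ in more than one place, so they could not show this. No measurement at hand explains the loss.

As far as these compounds go, it remains open whether the second ring or the lost methyl matters more. Plain phenyl or naphthalen-2-yl at this place could help separate the two.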